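Isopropyl to Butyl on the Shared Core

The compounds below may be only part of what the source reports. "The series", "measured", "known", "first", "only" and "open" are said of these compounds alone.

Of the compounds shown here, three built on the same core have been measured, and all three sit at the same limit. Compound 1 `CCc1cn([C@H]2C[C@@H]3OP(=O)(O)OC[C@H]3O2)c(=O)[nH]c1=O` is the smallest of them; in a functional assay on Raji cells (Homo sapiens) (on this read-out higher numbers stand for weaker inhibition and lower numbers for stronger inhibition), compound 1 gives only a limit of the assay, > 500 ug/mL. Compound 2 `CCCCCCc1cn([C@H]2C[C@@H]3OP(=O)(O)OC[C@H]3O2)c(=O)[nH]c1=O` carries a longer chain, and in this assay compound 2 likewise gives only a limit, > 500 ug/mL. Compound 3 `CC(C)c1cn([C@H]2C[C@@H]3OP(=O)(O)OC[C@H]3O2)c(=O)[nH]c1=O` is the branched member; in this assay compound 3 again gives only a limit, > 500 ug/mL. Compound 3 therefore stands exactly where the other two stand, at the limit of > 500 ug/mL in this assay, at which 3 of the 3 values shown sit, and none of the steps joining the measured compounds can be read: a step that the two limits leave unreadable from compound 1 to compound 3, a step that the two limits leave unreadable from compound 2 to compound 3 and a step that the two limits leave unreadable from compound 1 to compound 2 are all hidden by the limits.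

Compound 4 `CCCCc1cn([C@H]2C[C@@H]3OP(=O)(O)OC[C@H]3O2)c(=O)[nH]c1=O` differs from compound 3 in one place: butyl in place of isopropyl on an aromatic carbon. The measured steps that bear on this change give no readable size, so no step beyond the scatter is expected for a step that the limit leaves unreadable from compound 3 to compound 4. Compound 4 is expected to give 600 ug/mL in this assay, with a range from 250 ug/mL to 2000 ug/mL, most probably reported once more as a limit.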

Compound 4, concentration for 50% inhibition: 165 ug/mL
The estimate for compound 4 lay 3.6-fold (0.56 log units) above the measured number, outside the stated range (below it).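

In this assay, this position on the shared core can give a readable number: butyl in place of isopropyl produces an at least 3.0-fold lower number from compound 3 to compound 4 (0.48 log units; beyond the scatter). The gain is not a steady trend with chain length, as removing the far ethyl end of the hexyl chain gives an at least 3.0-fold lower number from compound 2 to compound 4 (0.48 log units; beyond the scatter), while adding ethyl to the end of the shorter chain gives an at least 3.0-fold lower number from compound 1 to compound 4 (0.48 log units; beyond the scatter), so compound 1, with the shorter chain, and compound 2, with the longer one, both go against any simple rule that longer is better or that shorter is better. Among the compounds shown, the unbranched butyl chain of compound 4 alone gives a number, and the other three remain at a limit of the assay: the limit of > 500 ug/mL in this assay, at which 3 of the 4 values shown sit.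

Going by these compounds, the steps among compounds 1, 2 and 3 cannot be read, and how far each of them lies from compound 4 remains unknown. On these data alone, it also remains open whether a propyl or pentyl chain at this position would give a number, and whether a hydroxyl group or an amine at the end of the butyl chain would keep the step.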